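Removing a 3,4-dichlorobenzyl group from compound 3

The source may hold more compounds than are shown below. What is called first, only, known or untested is meant among the compounds shown, and "the series" means these compounds.

In a functional assay on MCF7 cells (Homo sapiens) for inhibition, read by MTT assay, with a stated time of 72 h (a lower number here means a stronger inhibitor, a higher number a weaker inhibitor), compound 1 `C=CCc1ccc(OCc2ccc(Cl)cc2Cl)c(-c2ccc(O)c(CC=C)c2)c1` gives 27400 nM and compound 2 `C=CCc1ccc(O)c(-c2ccc(OCc3ccc(Cl)c(Cl)c3)c(CC=C)c2)c1` gives 15300 nM. Compound 3 `C=CCc1ccc(OCc2ccc(Cl)c(Cl)c2)c(-c2ccc(OCc3ccc(Cl)c(Cl)c3)c(CC=C)c2)c1` has only a limit, > 50000 nM, and no number. Compound 4 `C=CCc1ccc(OCc2ccc(Cl)c(Cl)c2)c(-c2ccc(O)c(CC=C)c2)c1` differs from compound 3 by hydrogen in place of 3,4-dichlorobenzyl on an oxygen on an aromatic ring, so that (3,4-dichlorobenzyl)oxy becomes hydroxy. Going by the values given here, the one measured step of this kind runs the opposite way, with 3,4-dichlorobenzyl in place of hydrogen on an oxygen on an aromatic ring: an at least 3.2-fold higher number from compound 2 to compound 3 (0.51 log units; beyond the scatter). A step of similar size toward a lower number is therefore expected in this assay, and the estimated step is an at least 2.5-fold lower number from compound 3 to compound 4 (0.39 log units; beyond the scatter). For compound 4 the expected value is 20000 nM, with an estimated range of 9000 nM to 45000 nM.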

Compound 4, half-maximal inhibitory concentration: 17500 nM
The estimate for compound 4 lay 1.1-fold (0.06 log units) above the measured number, within the range that was stated.
By their numbers in this assay, from the lowest: compounds 2, 4 and 1 (each within the scatter of the next). At a limit, above all of these: compound 3.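

Hydrogen in place of 3,4-dichlorobenzyl on this oxygen gives an at least 2.8-fold lower number from compound 3 to compound 4 (0.45 log units; beyond the scatter) in this assay, so compound 4, with its hydroxy, has a measured number, as does compound 2, which keeps its hydroxy on the other oxygen. That step is only a bound, because compound 3 stands at a limit: the limit of > 50000 nM in this assay, at which 1 of the 4 values shown sits.

Moving from 2,4-dichlorophenyl to 3,4-dichlorophenyl gives a 1.6-fold lower number from compound 1 to compound 4 (0.19 log units; within the scatter), so this change of chlorine pattern does not separate the two compounds. As far as these compounds go, what an amine, a carboxylic acid or a longer chain on this oxygen would do remains open.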